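The compounds below may be only part of what the source reports. "The series", "measured", "known", "first", "only" and "open" are said of these compounds alone.

Of the compounds shown here, three of one family have so far been tested in a functional assay on J774 cells (Mus musculus) for cytotoxicity, read by resazurin assay, with a stated time of 72 h; a higher number here means a weaker inhibitor, a lower number a stronger inhibitor. Compound 1 `O=S(=O)(Nc1cccc(CO)c1)c1ccc(-c2ccc(Br)cc2)cc1` gives 2500 nM, the highest of the three numbers. Compound 2 `O=S(=O)(Nc1cccc(CO)c1)c1ccc(-c2ccccc2F)cc1` gives 1300 nM, and compound 3 `O=S(=O)(Nc1cccc(CO)c1)c1ccc(-c2ccc(F)cc2F)cc1` gives 300 nM. The step of a 1.9-fold lower number from compound 1 to compound 2 (0.28 log units; within the scatter) is small, whereas an 8.3-fold lower number from compound 1 to compound 3 (0.92 log units; beyond the scatter) and a 4.3-fold lower number from compound 2 to compound 3 (0.64 log units; beyond the scatter) are larger. All three of these steps alter the outer ring at the far end of the shared core, exchanging a bromine for a fluorine or adding a second fluorine there.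

Compound 4 `Cc1c(CO)cccc1NS(=O)(=O)c1ccc(-c2ccc(Br)cc2)cc1` differs from compound 1 on a different ring of the shared core: methyl in place of hydrogen on an aromatic carbon, sitting ortho to a hydroxymethyl group. Going by the values given here, none of the measured steps touches that ring, so no measured step bears directly on the change from compound 1 to compound 4, and the measured steps give no hint in either direction. The added group is only a methyl. The expected step is therefore no change at the digits printed from compound 1 to compound 4 (within the scatter), that is, no movement beyond the usual scatter. On that basis compound 4 is estimated at 2500 nM, with a likely range from 1000 nM to 6000 nM.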

Compound 4, half-maximal inhibitory concentration: 750 nM
For compound 4 the middle estimate is 3.3-fold (0.52 log units) above the measured one, outside the stated range (below it).
By their numbers in this assay, from the lowest: compound 3; then compounds 4, 2 and 1 (each within the scatter of the next, the first and the last beyond it).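

In this assay, the methyl placed ortho to a hydroxymethyl group gives a 3.3-fold lower number from compound 1 to compound 4 (0.52 log units; beyond the scatter) and so carries the number beyond the scatter. Going by these compounds alone, this shows that the ring bearing the hydroxymethyl group, which no earlier step touched, can also change the result, and that a single added carbon there is enough; until now, only changes to the outer ring at the far end of the shared core had done so. No available measurement explains how this methyl lowers the number.

On these data alone, with a single substituent at this position, it remains open whether the effect belongs to methyl in particular or would also appear with an ethyl group, a chlorine atom, a methoxy group or an amine. It is also open whether the methyl would lower the number to a similar extent on a compound carrying the 2-fluorophenyl or 2,4-difluorophenyl group in place of the 4-bromophenyl group, since the compounds shown pair it only with the 4-bromophenyl group.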